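Acid to acylsulfonamide on the aryl ether oxygen: clearance outlook

This account rests on a few compounds, and the source may have more. Where it says the series, first, only, none or still open, it means among the compounds named here.

Three members of this series, all built on the shared core, have been run in an ADME assay on microsomes from liver (Mus musculus) for metabolic stability, using NADPH, with a stated time of 60 min, in the presence of a further agent that is not named here; a lower number here means slower removal, a higher number faster removal of the compound. Compound 1, `CC(=O)NC1C2CC3CC1CC(C2)C31OO[C@]2(CC[C@@H](c3ccc(OCC(=O)O)cc3)CC2)O1`, reaches only a limit of the assay in this assay, < 7 mL.min-1.g-1. Compound 2, `CC(C)(Oc1ccc([C@H]2CC[C@]3(CC2)OOC2(O3)C3CC4CC(C3)CC2C4)cc1)C(=O)O`, gives 7 mL.min-1.g-1 in this assay, the lowest of the two numbers reported so far. Compound 3, `O=C(O)c1cc([C@H]2CC[C@]3(CC2)OOC2(O3)C3CC4CC(C3)CC2C4)ccc1O`, gives 20 mL.min-1.g-1 in this assay, and its gap to compound 2 lies beyond the usual scatter. Within the data shown here, no two of these three differ in a single place, so no measured step can be drawn from them; the only firm anchor is the limit of < 7 mL.min-1.g-1 in this assay, at which 1 of the 3 values shown sits, which marks compound 1 as the member whose value the assay could not resolve.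

Compound 4, `CS(=O)(=O)NC(=O)COc1ccc([C@H]2CC[C@]3(CC2)OOC2(O3)C3CC4CC(C3)CC2C4)cc1`, awaits measurement in this assay. It differs from compound 2 in one place: ((methylsulfonyl)carbamoyl)methyl in place of 1-carboxy-1-methylethyl on an oxygen on an aromatic ring. With no measured step of this kind in the set, the expectation rests on compound 2 alone, which gives 7 mL.min-1.g-1 in this assay. Compound 4 is therefore expected to give 9 mL.min-1.g-1 in this assay, estimated between 4 mL.min-1.g-1 and 20 mL.min-1.g-1. The estimated step is a 1.3-fold higher number from compound 2 to compound 4 (0.11 log units; within the scatter), expected to fall within the scatter rather than beyond it, with no clear direction claimed; a limit-only result remains possible.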

Compound 4, intrinsic clearance in microsomes: 12 mL.min-1.g-1
Beside the measured number, compound 4's estimate is 1.3-fold (0.12 log units) below it; low and high end bracket the measured number.
By their numbers in this assay, from the lowest: compounds 2, 4 and 3 (each within the scatter of the next, the first and the last beyond it).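

Among these compounds, compound 4 gives the first measured step at this position on the aryl ether oxygen: in this assay, ((methylsulfonyl)carbamoyl)methyl in place of 1-carboxy-1-methylethyl gives a 1.7-fold higher number from compound 2 to compound 4 (0.23 log units; within the scatter). Compounds 1, 2 and 3 all carry a carboxylic acid, so compound 4 is the first shown without one, and on this single pair the swap cannot be told apart from compound 2 in this read-out. Nothing among the data shown offers a reason for the closeness of the two compounds, and the only limit in the set has no bearing on this pair.

The swap removes the carboxylic acid and the two methyl groups of the 1-carboxy-1-methylethyl group together, so the compounds shown do not separate these two parts; a carboxymethyl group on the same oxygen over the shared core would begin to do so. From the compounds shown here alone, whether this reading holds for a larger sulfonyl substituent, such as phenylsulfonyl in place of methylsulfonyl, or for a tetrazole at this place, remains open, as one pair supports no wider pattern.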